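A new group on the sulfonyl sulfur of compound 2

The compounds below may be only part of what the source reports. "The series", "measured", "known", "first", "only" and "open" are said of these compounds alone.

Measured in a functional assay on A2780 cells (Homo sapiens) for antiproliferative activity, read by sulforhodamine B assay, with a stated time of 72 h; a higher number here means a weaker inhibitor, a lower number a stronger inhibitor:
Compound 1 `Nc1ncc(CNC(=O)Nc2ccc(S(=O)(=O)c3ccccc3)cc2)cn1`: > 2000 nM
Compound 2 `O=C(NCc1cccnc1)Nc1ccc(S(=O)(=O)N2CC3(COC3)C2)cc1`: > 2000 nM

Neither compound has an exact number here, only a limit. Compound 2 stands at the limit of > 2000 nM in this assay, at which 2 of the 2 values shown sit.

Compound 3 `N[C@H]1CC[C@H](NS(=O)(=O)c2ccc(NC(=O)NCc3cccnc3)cc2)CC1` keeps the rest of compound 2 and changes one group: a group of 8 heavy atoms (6 carbon, 2 nitrogen; one six-membered non-aromatic ring of carbon only) in place of a group of 7 heavy atoms (5 carbon, 1 nitrogen, 1 oxygen; 2 four-membered non-aromatic rings with 1 hetero atom each), on a sulfonyl sulfur. A (4-aminocyclohexyl)amino group, with one six-membered non-aromatic ring of carbon only, takes the place of the group with two four-membered rings, on a sulfonyl sulfur.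

Within the data shown here, no measured pair shows what such a swap does, so any forecast starts from the limit of compound 2 at > 2000 nM. The estimated change is small, a step that the limit leaves unreadable from compound 2 to compound 3, and is not expected to go beyond the usual scatter. For compound 3 the expected half-maximal inhibitory concentration is 2500 nM, with an estimated range of 700 nM to 8000 nM.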

Compound 3, half-maximal inhibitory concentration: 52 nM
Compound 3: the middle estimate sits 48-fold (1.68 log units) above what was measured; the whole stated range lies above it.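

In this assay, placing a (4-aminocyclohexyl)amino group on the sulfonyl sulfur gives an at least 38-fold lower number from compound 2 to compound 3 (1.58 log units; beyond the scatter). Among these compounds, this shows that the group on this sulfur can decide whether the compound reaches an exact reading, which the earlier compounds could not show since neither gave one. The true size of the step stays unknown, and the figure is only a minimum, because compound 2 has no exact value: the limit of > 2000 nM in this assay, at which 2 of the 3 values shown sit.

The swap replaces the two four-membered rings with a carbon-only six-membered ring, and also brings in an amine and two defined stereocentres, so the compounds shown do not separate the share of each. A plain cyclohexylamino group, or a hydroxyl in place of the amine, would show whether the amine itself matters.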